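Lengthening methoxycarbonyl to butoxycarbonyl in compound 1

This account rests on a few compounds, and the source may have more. Where it says the series, first, only, none or still open, it means among the compounds named here.

For the measured compounds named here, in a functional assay on MOLT-4 cells (Homo sapiens) (on this read-out lower numbers stand for stronger inhibition and higher numbers for weaker inhibition), compound 1 `COC(=O)c1nn([C@@H]2O[C@H](CO)[C@@H](O)[C@H]2O)cc1I` gives 900 nM, the only true number available so far. Compound 2 `C#Cc1cn([C@@H]2O[C@H](CO)[C@@H](O)[C@H]2O)nc1C(N)=O` is reported only as a limit, > 300000 nM. That leaves compound 1 as the single firm reference point.

Compound 3 `CCCCOC(=O)c1nn([C@@H]2O[C@H](CO)[C@@H](O)[C@H]2O)cc1I` keeps the core of compound 1 and changes one place: propyl in place of hydrogen on a saturated chain carbon bound to an oxygen next to a carbonyl group. Put more simply, methyl becomes butyl, turning methoxycarbonyl into butoxycarbonyl. Going by the values given here, no pair of measured compounds tests a change of this kind, so any forecast rests on very little. A modest loss of inhibition in this assay seems the likeliest outcome, though a result within the usual scatter would be no surprise. The expected step of a 2.8-fold higher number from compound 1 to compound 3 (0.44 log units; beyond the scatter) is therefore an estimate, pointing towards weaker inhibition. For compound 3 the estimated value is 2500 nM, with an expected range from 400 nM to 20000 nM.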

Compound 3, half-maximal inhibitory concentration: 16000 nM
The estimate for compound 3 lay 6.4-fold (0.81 log units) below the measured number, and the stated range covers the measured number.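

In this assay, the group at this place on the core of compound 1 proves sensitive to chain length: turning methoxycarbonyl into butoxycarbonyl gives an 18-fold higher number from compound 1 to compound 3 (1.25 log units; beyond the scatter), a large move towards weaker inhibition. The inhibition is weakened but not lost, as compound 3 still gives a true number of 16000 nM. Nothing among the data shown explains why the longer chain costs this much inhibition.

On these data alone, whether the loss builds steadily with each added carbon or appears suddenly at one chain length remains open, and ethoxycarbonyl and propoxycarbonyl compounds would help to settle that. As far as these compounds go, it is also open whether a branched chain such as isopropyl, or a carboxylic acid in place of the methoxycarbonyl group, would keep or lose the inhibition seen with compound 1.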